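A few compounds are considered here, and "the series" means these few. Any claim that something is new, unique, unknown or untested is made for them only; others in the source may bear on it.

Measured compounds:
- compound 1, `CCN(CC)S(=O)(=O)c1ccc(S(=O)(=O)N2CCC[C@@H](C(=O)N3CCC(F)(F)CC3)C2)cc1`, 16 nM
- compound 2, `CCN(CC)S(=O)(=O)c1ccc(S(=O)(=O)N2CCC[C@@H](C(=O)N3CCS(=O)(=O)CC3)C2)cc1`, 900 nM
- compound 3, `CC(C)S(=O)(=O)c1ccc(S(=O)(=O)N2CCC[C@@H](C(=O)N3CCC(F)(F)CC3)C2)cc1`, 11 nM

All three share one core and were tested in a functional assay on MIA PaCa-2 cells (Homo sapiens) for inhibition, read by MTT assay, with a stated time of 7 days; on this read-out higher numbers stand for weaker inhibition and lower numbers for stronger inhibition. Compound 1 gives the second highest number of the three; compound 3 sits nearest, a 1.5-fold lower number from compound 1 to compound 3 (0.16 log units; within the scatter), while compound 2 lies furthest, a 56-fold higher number from compound 1 to compound 2 (1.75 log units; beyond the scatter).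

Compound 4, `CCN(CC)S(=O)(=O)c1ccc(S(=O)(=O)N2CCC[C@@H](C(=O)N3CC[C@@H](OC)C3)C2)cc1`, has not yet been measured. It differs from compound 1 only on a carbonyl carbon: 3-methoxypyrrolidin-1-yl in place of 4,4-difluoropiperidin-1-yl on a carbonyl carbon.

Within the data shown here, of the measured steps, only the one from compound 1 to compound 2 touches the same carbonyl carbon, and there a change of the ring on that carbon gave a 56-fold higher number from compound 1 to compound 2 (1.75 log units; beyond the scatter). The step from compound 1 to compound 3 concerns a sulfonyl sulfur elsewhere and says nothing about this position. With one example only, and a different group entering, a loss is expected, but a smaller one: for compound 4 the estimated step is a 9.4-fold higher number from compound 1 to compound 4 (0.97 log units; beyond the scatter). Compound 4 is therefore expected to give about 150 nM, with a likely range from 40 nM to 600 nM.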

Compound 4, half-maximal inhibitory concentration: 3910 nM
The estimate for compound 4 lay 26-fold (1.42 log units) below the measured number, and the stated range ends below it.
By their numbers in this assay, from the lowest: compounds 3 and 1 (each within the scatter of the next); then compound 2; then compound 4.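

In this assay, the carbonyl carbon turns out to be even less forgiving than the first example suggested: replacing the 4,4-difluoropiperidin-1-yl group with 3-methoxypyrrolidin-1-yl gives a 240-fold higher number from compound 1 to compound 4 (2.39 log units; beyond the scatter) and is the largest loss seen so far. The new group also falls short of 1,1-dioxothiomorpholin-4-yl, with a 4.3-fold higher number from compound 2 to compound 4 (0.64 log units; beyond the scatter) as the step between them, so the two replacements of 4,4-difluoropiperidin-1-yl both lose heavily but not equally. Nothing available here explains these losses.

This change alters both the ring size and the substituent at once, so a plain pyrrolidin-1-yl or a 3-methoxypiperidin-1-yl group would be needed to separate the two. Going by these compounds, it also remains open whether 3-methoxypyrrolidin-1-yl would cost as much with isopropyl on the sulfonyl sulfur, as in compound 3.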